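Working notes: 4-fluorophenyl to 4-methylphenyl

This account rests on a few compounds, and the source may have more. Where it says the series, first, only, none or still open, it means among the compounds named here.

Measured in an ADME assay on RAW264.7 cells (Mus musculus) for cytotoxicity, read by MTT assay, with a stated time of 48 h (on this read-out lower numbers stand for stronger inhibition and higher numbers for weaker inhibition), each entry a limit of the assay and not a number:
- compound 1 `O=C(NCCOC(=S)Nc1ccc(F)cc1)c1cccnc1`: > 800000 nM
- compound 2 `O=C(CCCCC1CCSS1)OCCCOC(=O)c1cccnc1`: > 800000 nM
- compound 3 `Cc1ccc(NC(=S)OCCNC(=O)C(C)(C)Oc2ccc(Cl)cc2)cc1`: > 800000 nM

Compound 1 has no number of its own and stands at the limit of > 800000 nM in this assay, at which 3 of the 3 values shown sit, so no order can be read among the measured compounds. Going by the values given here, no step between measured compounds is available either.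

The next compound to be measured is compound 4 `Cc1ccc(NC(=S)OCCNC(=O)c2cccnc2)cc1`. It differs from compound 1 at a single place: methyl in place of fluoro on an aromatic carbon, para to a large group. The rest of the structure is unchanged.

Compound 3 carries the 4-methylphenyl as well and also stands at a limit (> 800000 nM), and the expectation rests on that value. In this assay the expected change is a step that the limit leaves unreadable from compound 1 to compound 4, which is estimated to be nothing beyond the usual scatter, with no direction favoured.

Compound 4 is expected near 900000 nM, with an estimated range of 400000 nM to 2000000 nM, and will most likely be reported only as a limit.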

Compound 4, half-maximal inhibitory concentration: > 800000 nM
Compound 4 was reported as a limit; the forecaster's own chance of this, stated with the estimate: 85%; the middle value lies beyond the limit too.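

In this assay no step can be read between compound 1 and compound 4, since both stand only as limits: the limit of > 800000 nM in this assay, at which 4 of the 4 values shown sit. The compounds shown leave open where any of them would fall as an actual number, and so whether methyl in place of fluoro on an aromatic carbon changes this read-out at all.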